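Amide series with varied amino substituent on the pyridine

The compounds below may be only part of what the source reports. "The series", "measured", "known", "first", "only" and "open" are said of these compounds alone.

Measured compounds in a functional assay on CHO-K1 cells for antagonist activity at transient receptor potential cation channel subfamily V member 1 (Homo sapiens), read by FLIPR; on this read-out higher numbers stand for weaker inhibition and lower numbers for stronger inhibition:
- compound 1 `CCCCNc1nc(C(F)(F)F)ccc1CNC(=O)C(C)c1ccc(NS(C)(=O)=O)c(F)c1`: 9.1 nM
- compound 2 `CC(C)OC1CCN(c2nc(C(F)(F)F)ccc2CNC(=O)C(C)c2ccc(NS(C)(=O)=O)c(F)c2)CC1`: 3 nM
- compound 3 `CC(C(=O)NCc1ccc(C(F)(F)F)nc1N1CCCCCC1)c1ccc(NS(C)(=O)=O)c(F)c1`: 0.8 nM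

Compound 3 holds the lowest number of the three; the steps of an 11-fold lower number from compound 1 to compound 3 (1.06 log units; beyond the scatter) and a 3.8-fold lower number from compound 2 to compound 3 (0.57 log units; beyond the scatter) both lie beyond the scatter, so it counts as the strongest inhibitor among the measured compounds. Compound 4 `CC(C(=O)NCc1ccc(C(F)(F)F)nc1N1CCN(C2CCCCC2)CC1)c1ccc(NS(C)(=O)=O)c(F)c1` changes the same position: 4-cyclohexylpiperazin-1-yl in place of azepan-1-yl on an aromatic carbon. Among the measured compounds shown here, no measured step covers a two-ring group of this kind. The two steps that reach compound 3 show the azepanyl group giving lower numbers than either the butylamino or the 4-isopropoxypiperidinyl group, and compound 4 gives up that group. The estimate therefore places compound 4 back toward the range of compound 2, a step of a 3.8-fold higher number from compound 3 to compound 4 (0.57 log units; beyond the scatter) in this assay, with compound 4 expected at 3 nM (range 1 nM to 12 nM).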

Compound 4, inhibition constant: 21.6 nM
For compound 4 the middle estimate is 7.2-fold (0.86 log units) below the measured one; measured number outside the range, above it.
By their numbers in this assay, from the lowest: compound 3; then compound 2; then compound 1; then compound 4.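

At this position in this assay, 4-cyclohexylpiperazin-1-yl gives the highest number of the four, with a 27-fold higher number from compound 3 to compound 4 (1.43 log units; beyond the scatter) and a 7.2-fold higher number from compound 2 to compound 4 (0.86 log units; beyond the scatter) and a 2.4-fold higher number from compound 1 to compound 4 (0.38 log units; beyond the scatter) all beyond the scatter. A ring on this carbon therefore does not by itself give a lower number than butylamino: compounds 2 and 3 follow that order, and compound 4 goes against it. Nothing available explains the rise.

Going by these compounds, whether the rise follows the cyclohexyl ring or the second piperazine nitrogen stays open. A 4-cyclohexylpiperidin-1-yl or 4-methylpiperazin-1-yl group on the same carbon would separate the two.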